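Replacing pyridin-4-yl with 4-hydroxyphenyl: working notes

The source may report more compounds than this note shows. Statements on the series, on what has been measured and on what is new or still open speak of the compounds shown alone.

The series currently offers a single number in an ADME assay on MCF10 cells (Homo sapiens) for cytotoxicity; on this read-out lower numbers stand for stronger inhibition and higher numbers for weaker inhibition. Compound 1 (`CCc1nc(N)nc(N)c1C#CC(C)c1ccc(-c2ccccc2)cc1OC`) has the entry "not determined" (no result reported), so it provides no comparison. Compound 2 (`CCc1nc(N)nc(N)c1C#CC(C)c1ccc(-c2ccncc2)cc1OC`) gives 216000 nM, and with no second number beside it, this value cannot yet be ranked within the series.

Compound 3 (`CCc1nc(N)nc(N)c1C#CC(C)c1ccc(-c2ccc(O)cc2)cc1OC`) keeps the shared core of compound 2 and carries 4-hydroxyphenyl in place of pyridin-4-yl on an aromatic carbon, meta to a methoxy group: 4-hydroxyphenyl in place of pyridin-4-yl on an aromatic carbon.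

Within the data shown here, the series contains no measured step between two compounds, so nothing yet calibrates the effect of this exchange on this assay. Among the measured compounds shown here, the only anchor is compound 2 at 216000 nM, and the working assumption stays close to it. No step beyond the usual scatter is expected, and no firm direction can be assigned. The expected change is small: a 1.4-fold lower number from compound 2 to compound 3 (0.13 log units; within the scatter). The range is kept wide, since it rests on one measured value. For compound 3 the estimated value is 160000 nM, with an expected range of 50000 nM to 400000 nM.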

Compound 3, half-maximal inhibitory concentration: 148000 nM
Compound 3: middle estimate off by 1.1-fold (0.03 log units), on the high side, within the range that was stated.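

In this assay the series now has one measured step at this position, on an aromatic carbon meta to a methoxy group and para to a large group: a 1.5-fold lower number from compound 2 to compound 3 (0.16 log units; within the scatter). The exchange of pyridin-4-yl for 4-hydroxyphenyl, which brings in a hydrogen-bond donor and a carbon-only ring, therefore gives two compounds that this read-out cannot separate, and at this level of evidence the position accepts this one change without a step beyond the scatter. No supporting data bear on this result, so the notes offer no explanation for it.

Among these compounds, compound 1 has the entry "not determined" (no result reported), so steps involving it cannot be read, and the series offers only this single comparison for the position. Open questions are whether an amine or a carboxylic acid on the same ring, or a longer chain in place of the hydroxyl, would also stay within the scatter of compound 2 in this assay, and whether the present step would hold on a different core.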